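This account rests on a few compounds, and the source may have more. Where it says the series, first, only, none or still open, it means among the compounds named here.

In an ADME assay on L6 cells (Rattus norvegicus) for cytotoxicity, read by resazurin assay, with a stated time of 72 h (a lower number here means a stronger inhibitor, a higher number a weaker inhibitor), compound 1 (`CCN(CC)CC(=O)OC1CC2(N(C)C)CC(c3ccccc3)C1C(c1ccccc1)C2`) gives 30100 nM and compound 2 (`CN1CCN(CC(=O)NC2CC3(N4CCCC4)CC(c4ccccc4)C2C(c2ccccc2)C3)CC1`) gives 50200 nM so these two lie within the usual scatter of each other. Compound 3 (`CN1CCN(CCC(=O)N2CCC3(N4CCCCC4)CC(c4ccccc4)C2C(c2ccccc2)C3)CC1`) gives 120000 nM which is higher than the number for compound 2 by more than the scatter. Compound 4 (`CN1CCN(CCC(=O)NC2CC3(N4CCCC4)CC(c4ccccc4)C2C(c2ccccc2)C3)CC1`) differs from compound 2 in one place ((4-methylpiperazin-1-yl)methyl in place of 4-methylpiperazin-1-yl on a saturated chain carbon bound to a carbonyl carbon) with (4-methylpiperazin-1-yl)methyl in place of 4-methylpiperazin-1-yl on a saturated chain carbon bound to a carbonyl carbon. Within the data shown here, no measured pair shows this change alone. The estimated step of a 1.2-fold higher number from compound 2 to compound 4 (0.08 log units; within the scatter) is expected to stay within the scatter, with a slightly higher number at most. For compound 4 the estimated value is 60000 nM with an expected range from 28000 nM to 120000 nM in this measurement.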

Compound 4, half-maximal inhibitory concentration: 86700 nM
For compound 4 the middle estimate is 1.4-fold (0.16 log units) below the measured one, within the range that was stated.
By their numbers in this assay, from the lowest: compounds 1, 2, 4 and 3 (each within the scatter of the next, the first and the last beyond it).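

Among these compounds, this is the only measured pair that differs in one place: in this assay, (4-methylpiperazin-1-yl)methyl in place of 4-methylpiperazin-1-yl on a saturated chain carbon bound to a carbonyl carbon gives a 1.7-fold higher number from compound 2 to compound 4 (0.24 log units; within the scatter). At this position, this change alone therefore does not separate the two compounds beyond the usual scatter. Nothing measured here offers a cause for the result. Still open, on these data alone, is whether a longer chain, such as 3-(4-methylpiperazin-1-yl)propyl, or another amine at the chain end, such as morpholin-4-yl, would give a step beyond the scatter.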